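A Weakly Active Series and One Untested Substitution

The source may hold more compounds than are shown below. What is called first, only, known or untested is meant among the compounds shown, and "the series" means these compounds.

Compound 1 `Nc1nc(-c2ccccc2)nn1-c1ncnc2ccccc12`. In an assay on MCF7 cells for inhibition of Serine-protein kinase ATM (Homo sapiens), read by immunofluorescence, with a stated time of 1 h (a lower number here means a stronger inhibitor, a higher number a weaker inhibitor), compound 1 gives > 40000 nM, which is a limit of the assay rather than a number.
Compound 2 `COc1cc2ncnc(-n3nc(-c4ccccn4)nc3N)c2cc1[N+](=O)[O-]`. In this assay compound 2 gives 31100 nM.
Compound 3 `Nc1nc(-c2ccccn2)nn1-c1ncnc2cc(N3CCNCC3)c([N+](=O)[O-])cc12`. In this assay compound 3 gives > 40000 nM, again a limit of the assay.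

Among the three measured compounds, compound 2 is the only one with a real number; the other two sit at the limit, as the record shows (the limit of > 40000 nM in this assay, at which 2 of the 3 values shown sit). For the measured compounds named here, the one measured step is an at least 1.2-fold higher number from compound 2 to compound 3 (0.10 log units; that floor lies within the scatter), and its floor lies within the usual scatter, so it tells of no clear change.

Compound 4 `CCN(CC)C(=O)COc1cc2c(-n3nc(-c4ccccn4)nc3N)ncnc2cc1OC` differs from compound 2 in a single place: (diethylcarbamoyl)methoxy in place of nitro on an aromatic carbon. Going by the values given here, no measured step touches this change, since nitro is exchanged here for a group that appears nowhere among the measured compounds. Among the compounds with values here, the only step available concerns a different position and is flat. With the whole series weak, the expectation for compound 4 is a similarly weak number, estimated as a step of a 1.2-fold lower number from compound 2 to compound 4 (0.09 log units; within the scatter), with a real chance that only a limit is reported. The estimate for compound 4 in this assay is 25000 nM, ranging from 4000 nM to 100000 nM.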

Compound 4, half-maximal inhibitory concentration: 5300 nM
Estimate against measurement, compound 4: 4.7-fold (0.67 log units) above, within the range that was stated.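

In this assay, putting (diethylcarbamoyl)methoxy in place of nitro gives a 5.9-fold lower number from compound 2 to compound 4 (0.77 log units; beyond the scatter), the only step shown so far that lies beyond the scatter. This position, on an aromatic carbon ortho to a methoxy group, is therefore one where a single exchange clearly moves the number, and nitro is not needed for a measurable value, since compound 4 lacks it and compound 4 gives 5300 nM. The entering group has 9 heavy atoms against 3 for nitro, so a much larger chain at this position does not cost inhibition here, although the step is modest and compound 4 remains a fairly weak inhibitor.

The exchange replaces the whole group at once, so the compounds shown leave open which part of the chain carries the change: a plain methoxy, a carboxylic acid or a smaller amide at the same place would separate the ether oxygen, the carbonyl and the two ethyl groups. The values of compound 1 and compound 3 remain limits of the assay rather than numbers, and the series still has few real values to compare: the limit of > 40000 nM in this assay, at which 2 of the 4 values shown sit.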